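Trimming One Carbon on the Way from Compound 3 to Compound 4

The compounds below may be only part of what the source reports. "The series", "measured", "known", "first", "only" and "open" are said of these compounds alone.

Compound 1 `CCc1cc2ccccc2nc1-c1cn(-c2ccc(F)cc2)nn1`: in a functional assay on U-937 cells (Homo sapiens) for cytotoxicity, read by MTT assay, with a stated time of 24 h (on this read-out lower numbers stand for stronger inhibition and higher numbers for weaker inhibition), compound 1 gives > 100 ug/mL, which is a limit of the assay rather than a number.
Compound 2 `CCCCCCCCCCn1cc(-c2nc3ccccc3cc2CCCC)nn1`: in this assay compound 2 gives 25.2 ug/mL.
Compound 3 `CCCCCc1cc2ccccc2nc1-c1cn(CCC(F)(F)C(F)(F)C(F)(F)C(F)(F)C(F)(F)C(F)(F)C(F)(F)C(F)(F)F)nn1`: in this assay compound 3 gives > 100 ug/mL, again a limit of the assay.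

Compound 3 therefore stands at the limit of > 100 ug/mL in this assay, at which 2 of the 3 values shown sit. Only compound 2 reports a number. Within the data shown here, no step between two measured compounds that differ in one place is available, so the change to compound 4 `CCCCc1cc2ccccc2nc1-c1cn(CCC(F)(F)C(F)(F)C(F)(F)C(F)(F)C(F)(F)C(F)(F)C(F)(F)C(F)(F)F)nn1` rests on the structures alone: hydrogen in place of methyl on a saturated chain carbon, four bonds along the chain from an aromatic carbon.

The step that the limit leaves unreadable from compound 3 to compound 4 is expected to be none beyond the usual scatter. Compound 4 is estimated at 120 ug/mL, within 50 ug/mL to 300 ug/mL, and most probably it is again reported only as a limit.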

Compound 4, half-maximal inhibitory concentration: 59.1 ug/mL
For compound 4 the middle estimate is 2.0-fold (0.31 log units) above the measured one; the range from low to high includes it.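

With hydrogen in place of methyl on a saturated chain carbon, four bonds along the chain from an aromatic carbon, this assay gives a number for compound 4 rather than a limit. The change produces an at least 1.6-fold lower number from compound 3 to compound 4 (0.22 log units; that floor lies within the scatter). Its true size stays unread, since compound 3 has only a limit, which it shares with another compound: the limit of > 100 ug/mL in this assay, at which 2 of the 4 values shown sit.

The compounds shown leave open how the number would respond, with the rest of compound 4 kept, to a shorter propyl chain at this place. From the compounds shown here alone, an amine or a carboxylic acid at the chain end is equally open.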